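The source may hold more compounds than are shown below. What is called first, only, known or untested is meant among the compounds shown, and "the series" means these compounds.

Measured compounds in a functional assay on OVCAR-5 cells (Homo sapiens) for inhibition, read by sulforhodamine B assay, with a stated time of 48 h; a higher number here means that more compound is tolerated, a lower number that less compound is tolerated:

compound 1, `Nc1cc(N)c2nc(-c3ccccc3)c(Oc3ccc(Cl)c(Cl)c3)nc2c1`: < 100000 nM, a limit.
compound 2, `CCOC(=O)[C@H](CCC(=O)O)NC(=O)c1ccc(Sc2nc3cc(N)cc(N)c3nc2-c2ccccc2)cc1`: < 100000 nM, a limit.
compound 3, `COc1ccc(Sc2nc3cc(N)cc(N)c3nc2-c2ccccc2)cc1`: < 100000 nM, a limit.

Compound 3 stands at a limit of this assay, not at a number. For the measured compounds named here, the same holds for the other two measured compounds, so that the whole series so far rests on (the limit of < 100000 nM in this assay, at which 3 of the 3 values shown sit). Going by the values given here, the one recorded step, a step that the two limits leave unreadable from compound 1 to compound 3, is therefore unreadable in size and direction. Among the compounds with values here, compound 2 and compound 3 have no step recorded between them; their two values show only that each is a limit.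

Compound 4, `Nc1cc(N)c2nc(-c3ccccc3)c(Sc3ccc(F)cc3)nc2c1`, differs from compound 3 by fluoro in place of methoxy on an aromatic carbon. Within the data shown here, no measured step bears on this change: the step from compound 1 to compound 3 has no readable size, and no other measured pair touches the same position. In this assay the expected step that the limit leaves unreadable from compound 3 to compound 4 is estimated as none beyond the scatter, since the starting point is itself a limit. Compound 4 is expected at about 30000 nM, with a range from 5000 nM to 100000 nM, and most likely again reported as a limit rather than a number.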

Compound 4, concentration lethal to 50% of the cells: < 100000 nM
Compound 4: only a limit was reported (the forecaster's own chance of this, stated with the estimate: 70%); the middle value is on the limit's open side.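

In this assay compound 4 gives < 100000 nM, a limit and not a number. The steps to compound 4 from compound 3 and from compound 1 cannot be read, because the series rests on one value: the limit of < 100000 nM in this assay, at which 4 of the 4 values shown sit. Left open is where each compound truly lies, and so whether fluoro in place of methoxy changes anything.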